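Swapping a Sulfonamide Tail for Trifluoromethyl: Expected Cytotoxicity

This account rests on a few compounds, and the source may have more. Where it says the series, first, only, none or still open, it means among the compounds named here.

Compound 2 `Cc1nc(NCCNS(C)(=O)=O)nc(N[C@@H]2C[C@H](CO)[C@@H](O)[C@H]2O)c1-c1nc2ccccc2s1` was examined in an ADME assay on cells (Homo sapiens) for cytotoxicity, read by polymerase chain reaction, with a stated time of 3 days; on this read-out lower numbers stand for higher toxicity in this test and higher numbers for lower toxicity in this test. In this assay compound 2 gives > 25000 nM, which is a limit of the assay rather than a number. Compound 1 `CCOCCNc1nc(C)c(-c2nc3ccccc3s2)c(N[C@@H]2C[C@H](CO)[C@@H](O)[C@H]2O)n1`, carrying an ethoxy group at the same place on the chain, gives 18000 nM in this assay. For the measured compounds named here, the single measured step, an at least 1.3-fold higher number from compound 1 to compound 2 (0.14 log units; that floor lies within the scatter), therefore shows nothing beyond the scatter, and the limit of > 25000 nM in this assay, at which 1 of the 2 values shown sits, records where compound 2 stands.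

Compound 3 `Cc1nc(NCCC(F)(F)F)nc(N[C@@H]2C[C@H](CO)[C@@H](O)[C@H]2O)c1-c1nc2ccccc2s1` is the compound not yet measured. It differs from compound 2 in one place: trifluoromethyl in place of methanesulfonamido on a saturated chain carbon, two bonds along the chain from a nitrogen on an aromatic ring. Going by the values given here, no measured step covers this exact exchange; the only step available, an ethoxy replaced by a methanesulfonamido group on the same chain carbon, stayed within the scatter. The expectation for this assay is accordingly a step of a number no higher from compound 2 to compound 3 (the limit leaves the size open), with no change beyond the scatter. Compound 3 is estimated to give 25000 nM in this assay, with a range from 12000 nM to 60000 nM, and a limit rather than a number is again considered the more likely outcome.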

Compound 3, half-maximal cytotoxic concentration: 9000 nM
Compound 3: the middle estimate sits 2.8-fold (0.44 log units) above what was measured, and the stated range ends above it.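

For the compounds shown here, on this chain carbon, the exchange of methanesulfonamido for trifluoromethyl produces the first step beyond the scatter in this assay (an at least 2.7-fold lower number from compound 2 to compound 3 (0.44 log units; beyond the scatter)), so the group carried here can move this read-out, in this case towards higher toxicity in this test. Going by these compounds alone, the exchange of ethoxy for trifluoromethyl, by contrast, stays within the scatter (a 2.0-fold lower number from compound 1 to compound 3 (0.30 log units; within the scatter)), so compound 1 and compound 3 cannot be placed in any order, and only the pair with the methanesulfonamido group shows a clear separation. For compound 2 the reading is a limit of the assay and not a number, so the step to compound 3 can only be read as a floor: the limit of > 25000 nM in this assay, at which 1 of the 3 values shown sits.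

The compounds shown do not tell whether the separation comes from the loss of methanesulfonamido or from the arrival of trifluoromethyl, and they give no cause for it. As far as these compounds go, how a carboxylic acid, an amine or a longer chain at this place would read in this assay remains open, as does whether this step would hold on a different core.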